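The source may hold more compounds than are shown below. What is called first, only, known or untested is meant among the compounds shown, and "the series" means these compounds.

Within the data shown here, compound 2 `CC(C)CCOC(=O)/C(C#N)=C/c1cc2ccccc2[nH]1` stands at the bottom of the two numbers measured so far in a functional assay on the whole organism (strain CD1) for inhibition, with Mus musculus as the target, with stated times of 15 min and 20 min, at a dose of 10 mg/kg by the subcutaneous route (on this read-out lower numbers stand for less inhibition and higher numbers for more inhibition at the one dose given (going by the name of the read-out)), giving 46.6%. Among the measured compounds shown here, its only neighbour, compound 1 `CCOC(=O)/C(C#N)=C/c1cc2ccccc2[nH]1`, gives 88.4% in this assay, and the single measured step, a number 41.8 percentage points lower from compound 1 to compound 2 (beyond the scatter), came from isopropyl in place of hydrogen on a saturated chain carbon, two bonds along the chain from an oxygen next to a carbonyl group. Compound 3 `N#C/C(=C\c1cc2ccccc2[nH]1)C(=O)OC1CCCCC1` differs from compound 2 by cyclohexyl in place of isopentyl on an oxygen next to a carbonyl group. The measured step bears on this change only loosely: it shows that a larger group on the ester oxygen of the shared core went with much lower inhibition, but here one group of five carbons is exchanged for a ring of six, so no step beyond the scatter is expected in this assay for compound 3, with a slight lean downward, giving an estimated a number 6.6 percentage points lower from compound 2 to compound 3 (within the scatter). Compound 3 is therefore estimated at 40%, within 18% to 64%.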

Compound 3, a percentage reported as inhibition, in the whole organism at one dose (the size of the read-out at that dose, not a potency): 83.6%
For compound 3 the middle estimate is 43.6 percentage points below the measured one; measured number above the stated range.
By their numbers in this assay, from the lowest: compound 2; then compounds 3 and 1 (each within the scatter of the next).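

In this assay, cyclohexyl in place of isopentyl on an oxygen next to a carbonyl group gave a number 37 percentage points higher from compound 2 to compound 3 (beyond the scatter) and so reversed most of the earlier loss, which means that inhibition does not simply fall as the group on this oxygen grows; compound 2 goes against such a pattern, and compound 3 does not fit it. Cyclohexyl in place of ethyl gave a number 4.8 percentage points lower from compound 1 to compound 3 (within the scatter) in this assay, so among the three compounds only the isopentyl ester stands apart. Nothing measured here gives a reason for the gap between the open isopentyl chain and the cyclohexyl ring.

The compounds shown leave open whether the low number belongs to the branch of isopentyl or to the length of its chain, which an unbranched pentyl chain would separate. They also leave open how a phenyl ring, or an amine on the ester chain, would fare on this oxygen.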